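Replacing 3-chlorophenyl with 4-methoxyphenyl in compound 2

The compounds below may be only part of what the source reports. "The series", "measured", "known", "first", "only" and "open" are said of these compounds alone.

In a functional assay on SW-620 cells (Homo sapiens) for cytotoxicity, read by MTT assay, with a stated time of 72 h (a lower number here means a stronger inhibitor, a higher number a weaker inhibitor), compound 1 (`COc1cccc(/C=C2\CCC/C(=C\c3cc(OC)c(OC)c(OC)c3)C2=O)c1OC`) gives 2500 nM. Compound 2 (`COc1ccc(/C=C2\CCC/C(=C\c3cccc(Cl)c3)C2=O)cc1OC`) gives 5100 nM, the higher of the two numbers and so the weaker result, and the gap between the two lies beyond the usual scatter of repeated measurements.

Compound 3 (`COc1ccc(/C=C2\CCC/C(=C\c3ccc(OC)c(OC)c3)C2=O)cc1`) has not yet been measured. It differs from compound 2 in one place: 4-methoxyphenyl in place of 3-chlorophenyl on a double-bonded chain carbon bound to a double-bonded ring carbon.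

Within the data shown here, no two measured compounds differ in just one place, so this change has no direct precedent. Like compound 3, the only guide, compound 1, carries methoxy groups and no chlorine, and compound 1 gives 2500 nM. The expectation is a modest drop, an estimated 1.7-fold lower number from compound 2 to compound 3 (0.23 log units; within the scatter), which stays within the scatter. Two measured values are a thin basis, so the range is kept wide. The estimate in this assay for compound 3 is 3000 nM, with an expected range from 1000 nM to 9000 nM.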

Compound 3, half-maximal inhibitory concentration: 6600 nM
Estimate against measurement, compound 3: 2.2-fold (0.34 log units) below; measured number inside the range.
By their numbers in this assay, from the lowest: compound 1; then compounds 2 and 3 (each within the scatter of the next).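

In this assay, among these compounds, the one change at this position gives a 1.3-fold higher number from compound 2 to compound 3 (0.11 log units; within the scatter). Among the compounds shown here, this is the first pair that differs in just one place, and it shows that on a double-bonded chain carbon bound to a double-bonded ring carbon, 3-chlorophenyl and 4-methoxyphenyl cannot be told apart by this measurement, even though only the entering group contains a hydrogen-bond acceptor. No measurement of any property of these groups accompanies the result, so the data give no explanation for this similarity.

The compounds shown leave open how far this tolerance extends: a ring carrying an amine or a carboxylic acid, or a longer chain in place of the ring, could give a clearly different number at the same carbon. Going by these compounds, compound 1 differs from compound 2 and compound 3 in more than one place, and which of those differences matters for its number also remains open.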